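Amide Chain Length on Two Related Cores

This account rests on a few compounds, and the source may have more. Where it says the series, first, only, none or still open, it means among the compounds named here.

In an ADME assay on P388D1 cells (Mus musculus) for cytotoxicity, read by fluorescence and resazurin assay, with a stated time of 72 h (a higher number here means a weaker inhibitor, a lower number a stronger inhibitor), three compounds have been measured so far, and each of the three values is a limit of the assay rather than a number.

Compound 1, `O=C(CCC1CCCCC1)Nc1ncc(Cc2cccc3sccc23)s1`: > 40000 nM
Compound 2, `O=C(Nc1ncc(Cc2cccc3sccc23)s1)C1CCCCC1`: > 40000 nM
Compound 3, `O=C(Nc1ncc(Cc2cccc3ccsc23)s1)C1CCCCC1`: > 40000 nM

Compound 2 and compound 1 differ in one place, (2-cyclohexylethyl in place of cyclohexyl on a carbonyl carbon). The step that the two limits leave unreadable from compound 2 to compound 1 cannot be read, because both compounds sit at the limit of > 40000 nM in this assay, at which 3 of the 3 values shown sit. Compound 3 has the same atoms as compound 2 joined differently; the difference between the two cores is not broken down here.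

Compound 4, `O=C(CCC1CCCCC1)Nc1ncc(Cc2cccc3ccsc23)s1`, has not yet been measured in this assay. It differs from compound 3 by 2-cyclohexylethyl in place of cyclohexyl on a carbonyl carbon, the same change that separates compound 2 from compound 1, at the same kind of place.

Compound 4 is expected to give about 50000 nM in this assay, between 20000 nM and 200000 nM. The expected step that the limit leaves unreadable from compound 3 to compound 4 is small. This expectation rests on compound 3 sitting at a limit, > 40000 nM, and on the earlier step that the two limits leave unreadable from compound 2 to compound 1 showing no readable change.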

Compound 4, half-maximal inhibitory concentration: 18900 nM
Compound 4: the middle estimate sits 2.6-fold (0.42 log units) above what was measured, outside the stated range (below it).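

In this assay, as far as these compounds go, putting 2-cyclohexylethyl in place of cyclohexyl on a carbonyl carbon gives an at least 2.1-fold lower number from compound 3 to compound 4 (0.32 log units; beyond the scatter), so on the core of compound 3 the change lowers the number by more than the usual scatter, and the full size of that step remains unknown. Going by these compounds alone, on the core of compound 2, the same change cannot be read, because compound 2 and compound 1 both sit at a limit of the assay: the limit of > 40000 nM in this assay, at which 3 of the 4 values shown sit. The single readable step therefore shows the effect of the change on one core only, and it shows neither that the change carries over to the core of compound 2 nor that it fails to do so.

The compounds shown leave open whether a longer chain between the carbonyl carbon and the cyclohexyl ring would lower the number further on the core of compound 3. They also leave open whether an amine or a carboxylic acid in place of cyclohexyl would keep the number at the level of compound 4.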